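From Chloro to Fluoro on a Shared Fused Core

A few compounds are considered here, and "the series" means these few. Any claim that something is new, unique, unknown or untested is made for them only; others in the source may bear on it.

Of the compounds shown here, three have been measured in an assay on isolated protein for displacement of a labelled ligand from tyrosine-protein kinase TEC (Mus musculus), read by fluorescence polarization; a higher number here means that more compound is needed for the effect, a lower number that less compound is needed. Compound 1, `Nc1ccc2c(n1)CCCC2`, gives 215000 nM. Compound 2, `Nc1ccc2cc(Cl)ccc2n1`, gives 76000 nM. Compound 3, `Nc1ccc2cc(C3OCCCO3)ccc2n1`, gives 26000 nM. Compound 2 therefore stands second highest of the three numbers: compound 1 sits at a higher number, beyond the usual scatter, and compound 3 sits at a lower number, also beyond the scatter.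

The unmeasured compound 4, `Nc1ccc2cc(F)ccc2n1`, differs from compound 2 in one place: fluoro in place of chloro on an aromatic carbon. Among the measured compounds shown here, exchanging one halogen for another on the same aromatic carbon of the shared core is a small change, and no measured pair here shows what such a swap does in this assay. The expectation is a step of a 1.3-fold higher number from compound 2 to compound 4 (0.12 log units; within the scatter) from the value of compound 2, a small move toward a higher number that may well fall within the scatter. Compound 4 is thus estimated at 100000 nM, with a range from 40000 nM to 250000 nM.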

Compound 4, half-maximal effective concentration: 150000 nM
For compound 4 the middle estimate is 1.5-fold (0.18 log units) below the measured one; the measured number falls inside the stated range.
By their numbers in this assay, from the lowest: compound 3; then compounds 2, 4 and 1 (each within the scatter of the next, the first and the last beyond it).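

Fluoro in place of chloro on this aromatic carbon of the shared core gives the first comparison in this assay between compounds that differ in one place, and it reads a 2.0-fold higher number from compound 2 to compound 4 (0.30 log units; within the scatter). At this position, meta to a fused ring and para to a fused ring, the assay therefore does not separate these two halogens, so this swap alone gives no firm sign of a change in the number. No other measurement is available to explain this result.

Still open, going by these compounds, is whether a different group on the same carbon, such as an amine, a methoxy group or a carboxylic acid, would produce a step beyond the scatter. Also open, on these data alone, is how an acetyl group on the amino nitrogen would read in this assay, with the halogen kept unchanged.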